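Chloro to nitro on the aryl group of compound 3

The source may report more compounds than this note shows. Statements on the series, on what has been measured and on what is new or still open speak of the compounds shown alone.

In a functional assay on MCF7 cells (Homo sapiens) for cytotoxicity, read by MTT assay, with a stated time of 96 h (a lower number here means a stronger inhibitor, a higher number a weaker inhibitor), compound 1 (`COc1cc(C(=O)c2cn(-c3ccc([N+](=O)[O-])cc3)cc2-c2ccccc2)cc(OC)c1OC`) gives 4000 nM and compound 2 (`COc1ccc(-n2cc(C(=O)c3cc(OC)c(OC)c(OC)c3)c(-c3ccccc3)c2)cc1`) gives 120 nM. Compound 3 (`COc1cc(C(=O)c2cn(-c3ccccc3)cc2-c2cccc(Cl)c2)cc(OC)c1OC`) gives 540 nM, the middle number of the three, with its gaps to both others beyond the scatter.

Compound 4 (`COc1cc(C(=O)c2cn(-c3ccccc3)cc2-c2cccc([N+](=O)[O-])c2)cc(OC)c1OC`) follows from compound 3 by nitro in place of chloro on an aromatic carbon.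

Among the compounds with values here, no measured pair shows this exchange directly. The nearest evidence is a 33-fold lower number from compound 1 to compound 2 (1.52 log units; beyond the scatter), a large step beyond the scatter, with methoxy in place of nitro on an aromatic carbon. That step sits at a different place on the molecule and starts from a different partner group, so it bears on the present change only loosely. It still points towards a higher number for the nitro compound, though a smaller step than that one seems likely.

The expected change is a 2.8-fold higher number from compound 3 to compound 4 (0.44 log units; beyond the scatter), towards weaker inhibition. For compound 4 the estimated value is 1500 nM, with an expected range of 400 nM to 6000 nM.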

Compound 4, half-maximal inhibitory concentration: 50 nM
Estimate against measurement, compound 4: 30-fold (1.48 log units) above; the whole stated range lies above it.
By their numbers in this assay, from the lowest: compound 4; then compound 2; then compound 3; then compound 1.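

In this assay, the exchange of 3-chlorophenyl for 3-nitrophenyl gives an 11-fold lower number from compound 3 to compound 4 (1.03 log units; beyond the scatter), so this position responds strongly to the group it carries, and nitro here goes with the lower number. Within the data shown here, the only earlier nitro compound sits at the far end of a 33-fold lower number from compound 1 to compound 2 (1.52 log units; beyond the scatter), at a different place on the molecule, and the present step shows that the high number of that compound does not carry over to this position. No measurement on hand bears on what lies behind the step.

The compounds shown carry only chloro and nitro at this position, so how an amine or a nitrile would compare here stays open. On these data alone, whether the same exchange would give a step of similar size at another carbon of this ring also stays open.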